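The source may hold more compounds than are shown below. What is called first, only, known or untested is meant among the compounds shown, and "the series" means these compounds.

Measured compounds:
- compound 1, `Fc1ccc(-c2ccc3cc(-c4cccnc4)ccc3c2)cc1`: 22%
- compound 2, `Fc1ccc(-c2ccc3c(Cn4ccnc4)cccc3c2)cc1`: 19%
- compound 3, `COc1ccc2cc(-c3ccc(F)cc3)ccc2c1Cn1ccnc1`: 45%

In an assay for inhibition of steroid 17-alpha-hydroxylase/17,20 lyase (Homo sapiens), tested at 2 uM (on this read-out higher numbers stand for a stronger effect at the one concentration tested and lower numbers for a weaker effect), compound 1 gives 22%, the second highest of the three numbers. Its nearest neighbour is compound 2, whose 19% lies within the scatter of it, so no order between the two can be read. Going by the values given here, compound 3 stands furthest away with 45%, a gap beyond the scatter; the one step computed within the set, a number 26 percentage points higher from compound 2 to compound 3 (beyond the scatter), comes from methoxy in place of hydrogen on an aromatic carbon and so does not speak to the change at hand.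

Compound 4, `Fc1ccc(-c2ccc3cc(Cn4ccnc4)ccc3c2)cc1`, has not yet been measured in this assay. Relative to compound 1 it carries (1H-imidazol-1-yl)methyl in place of pyridin-3-yl on an aromatic carbon. Among the compounds with values here, no measured step covers this exchange. What can be said is that compound 2, which already bears the (1H-imidazol-1-yl)methyl group on its core, gives a number within the scatter of compound 1, so there is no sign in these data that the imidazole group pulls the read-out up or down on its own. On that basis compound 4 is expected to sit close to compound 1, with an estimated step of no change at the digits printed from compound 1 to compound 4 (within the scatter), that is, none beyond the scatter. The estimate for compound 4 is therefore 22%, within a range from 6% to 40%.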

Compound 4, a percentage reported as inhibition, at one concentration (the size of the read-out at that concentration, not a potency): 14%
Estimate against measurement, compound 4: 8 percentage points above; the range from low to high includes it.
By their numbers in this assay, from the lowest: compounds 4, 2 and 1 (each within the scatter of the next); then compound 3.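

In this assay the exchange now has a direct reading at this position: a number 8 percentage points lower from compound 1 to compound 4 (within the scatter), so compound 1 and compound 4 cannot be put in any order. At this aromatic carbon, meta to a fused ring and para to a fused ring, the read-out at this one concentration therefore does not tell pyridin-3-yl, a six-membered aromatic ring with 1 hetero atom, from (1H-imidazol-1-yl)methyl, a five-membered aromatic ring with 2 hetero atoms joined through its methyl carbon. No other measurement bears on this result, so the data offer no account of why the two groups cannot be told apart.

From the compounds shown here alone, it remains open whether a different group at this position, such as an amine, a carboxylic acid or a longer chain carrying the imidazole, would give a number beyond the scatter of compound 1. Going by these compounds, it is also open whether methoxy, which accounts for a number 26 percentage points higher from compound 2 to compound 3 (beyond the scatter), would have a comparable effect on compound 4, where the (1H-imidazol-1-yl)methyl group stands at a different place on the shared core.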